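Swapping the Aryl Group on a Shared Core

The source may hold more compounds than are shown below. What is called first, only, known or untested is meant among the compounds shown, and "the series" means these compounds.

compound 1 `COC(=O)C1=C(C)N=C(C)/C(=C(\O)OC)C1c1ccc(Cl)cc1`: 8130 nM
compound 2 `COC(=O)C1=C(C)N=C(C)/C(=C(\O)OC)C1c1cccc([N+](C)(C)C)c1`: 50100 nM

In a functional assay (muscle tissue) with Cavia porcellus as the target (a lower number here means that less compound is needed, a higher number that more compound is needed for the effect), compound 1 stands at the lowest of the two measured numbers, while compound 2 gives a number well above it, beyond the usual scatter. Compound 3 `COC(=O)C1=C(C)N=C(C)/C(=C(\O)OC)C1c1c(Cl)cccc1Cl` differs from compound 1 by a single change: 2,6-dichlorophenyl in place of 4-chlorophenyl on a saturated ring carbon. Among the measured compounds shown here, no step of this kind has been measured here, so its size in this assay is a matter of expectation alone. Compound 3 is expected to move toward a lower number, by a step of a 3.3-fold lower number from compound 1 to compound 3 (0.51 log units; beyond the scatter). Compound 3 is estimated at 2500 nM, within a range from 500 nM to 15000 nM.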

Compound 3, half-maximal effective concentration: 1.91 nM
Beside the measured number, compound 3's estimate is 1300-fold (3.12 log units) above it; measured number outside the range, below it.
By their numbers in this assay, from the lowest: compound 3; then compound 1; then compound 2.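

In this assay, among the compounds shown here, the change to 2,6-dichlorophenyl in place of 4-chlorophenyl on the saturated ring carbon gives a 4300-fold lower number from compound 1 to compound 3 (3.63 log units; beyond the scatter) and is the first step that can be read at this position. It shows that the number in this assay responds very strongly to which chlorinated phenyl group sits there on the shared core. No available evidence accounts for the size of this step.

The compounds shown leave open whether the added chlorine or the new arrangement of chlorines carries the step. They also leave open whether a nitrophenyl or a trifluoromethylphenyl group would give a similarly low number.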